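Sulfamate benzamides: a smaller amine replaces the bromobenzyl group

The compounds below may be only part of what the source reports. "The series", "measured", "known", "first", "only" and "open" are said of these compounds alone.

Compound 1 `NS(=O)(=O)Oc1ccc2c(c1)CN(C(=O)c1cccc(N3CCN(c4ncccn4)CC3)c1)CC2` and compound 2 `CCN(Cc1ccc(Br)cc1)c1ccc(C(=O)N2CCc3ccc(OS(N)(=O)=O)cc3C2)cc1` share a sulfamate-bearing core and differ only in the group carried by the benzamide. In an assay on HEK293 cells for inhibition of Steryl-sulfatase (Homo sapiens), tested at 1 uM (on this read-out higher numbers stand for a stronger effect at the one concentration tested and lower numbers for a weaker effect), compound 1 gives 24.4%, while compound 2 gives 95.9%. Compound 2 thus stands highest of the two numbers, and its gap to compound 1 lies beyond the scatter. Compound 3 `CCCN(CCC)c1ccc(C(=O)N2CCc3ccc(OS(N)(=O)=O)cc3C2)cc1` keeps the core of compound 2 and changes the substituent on an aromatic carbon: dipropylamino in place of (4-bromobenzyl)(ethyl)amino on an aromatic carbon The group that enters has no ring and fewer heavy atoms than the one that leaves. For the measured compounds named here, no step between measured compounds that differ in one place is available to anchor the size of this change. A moderate fall in this assay is expected, a number 20.9 percentage points lower from compound 2 to compound 3 (beyond the scatter), because compound 2 gives 95.9% and leaves little room upward. Compound 3 is estimated at 75%, with a range from 40% to 95%.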

Compound 3, a percentage reported as inhibition, at one concentration (the size of the read-out at that concentration, not a potency): 84.7%
For compound 3 the middle estimate is 9.7 percentage points below the measured one, within the range that was stated.
By their numbers in this assay, from the lowest: compound 1; then compound 3; then compound 2.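

In this assay, replacing (4-bromobenzyl)(ethyl)amino with dipropylamino on this aromatic carbon, para to a large group, gives a number 11.2 percentage points lower from compound 2 to compound 3 (beyond the scatter), a modest step. A high reading at the one concentration tested therefore does not depend on the aromatic ring or the bromine of the group that leaves: compound 3, with no ring in this group and fewer heavy atoms, still gives 84.7%. Nothing available bears on the reason for the step.

From the compounds shown here alone, the ring, the bromine and the ethyl group all leave together, so their separate shares in the step remain open, and an unsubstituted benzyl group in place of the 4-bromobenzyl group would separate the bromine from the ring. Going by these compounds, how far the amine can shrink also remains open, with diethylamino or dimethylamino as the next groups in that direction.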